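The source may hold more compounds than are shown below. What is called first, only, known or untested is meant among the compounds shown, and "the series" means these compounds.

In a functional assay on the whole organism with Rattus norvegicus as the target, at a dose of 20 mg/kg by the oral route (on this read-out lower numbers stand for less inhibition and higher numbers for more inhibition at the one dose given (going by the name of the read-out)), three compounds of one shared core have been measured. Compound 1 `CNC(=O)/C=C1\CCc2ccc(Br)cc21` gives 44%, compound 2 `O=C(/C=C1\CCc2ccc(F)cc21)NCCO` gives 42%, and compound 3 `NC(=O)/C=C1\CCc2ccc(Br)cc21` gives 38%. Compound 3 carries the lowest of the three numbers, yet its gaps to compound 2 and to compound 1 both lie within the scatter, so the three cannot be told apart on these data.

One single-point step is known: a number 6 percentage points lower from compound 1 to compound 3 (within the scatter), a hydrogen in place of methyl on an amide-type nitrogen. That step touches the amide end of the molecule, not the aromatic ring, and it lies within the scatter.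

Compound 4 `COc1ccc2c(c1)/C(=C/C(N)=O)CC2` is still to be measured. It differs from compound 3 in this way: methoxy in place of bromo on an aromatic carbon. Within the data shown here, no measured step changes the aromatic substituent on its own; compound 2 differs from compound 1 and compound 3 in two places at once, so its value shows only that a fluoro analogue with a different amide sits in the same band. On the measured steps, none of which moves beyond the scatter, no step beyond the scatter is expected for no change at the digits printed from compound 3 to compound 4 (within the scatter). Compound 4 is therefore estimated at 38%, within 20% to 56%.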

Compound 4, a percentage reported as inhibition, in the whole organism at one dose (the size of the read-out at that dose, not a potency): 1%
Compound 4: middle estimate off by 37 percentage points, on the high side; the whole stated range lies above it.
By their numbers in this assay, from the lowest: compound 4; then compounds 3, 2 and 1 (each within the scatter of the next).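

In this assay, among these compounds, methoxy in place of bromo on this aromatic carbon, meta to a fused ring and para to a fused ring, gives a number 37 percentage points lower from compound 3 to compound 4 (beyond the scatter) and is the first step to lie beyond the scatter. Among the compounds shown here, the earlier compounds held no step that changed the aromatic substituent on its own, and their one single-point step, on the amide nitrogen, stayed within the scatter, so this position had not yet been tested. No measurement at hand bears on why this change has so large an effect.

The compounds shown do not separate the entry of methoxy from the loss of bromo, since the only other substituent at this place is fluoro, and it comes with a different amide. From the compounds shown here alone, how a hydroxyl, an amine or a methyl would read at this same aromatic carbon stays open, as does whether methoxy would give a similar number alongside the methyl amide of compound 1.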